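This account rests on a few compounds, and the source may have more. Where it says the series, first, only, none or still open, it means among the compounds named here.

Three diaryl ureas were examined in a functional assay on cells (Mus musculus) for antiproliferative activity, read by sulforhodamine B assay, with a stated time of 5 days; a lower number here means a stronger inhibitor, a higher number a weaker inhibitor. Compound 1, `Cc1ccc(NC(=O)Nc2ccc(Cl)c(C(F)(F)F)c2)cc1O`, carries a hydroxy group on its first ring. Compound 2, `COc1cc(NC(=O)Nc2cc(C(F)(F)F)cc(C(F)(F)F)c2)ccc1C`, and compound 3, `COc1cc(NC(=O)Nc2ccc(Cl)c(C(F)(F)F)c2)ccc1C`, each carry a methoxy group at that position but differ in the second ring; how the two cores differ is not broken down here.

In this assay compound 2 gives 6600 nM, and compound 3 gives 18600 nM. Compound 1 returns only a limit in this assay, > 20000 nM. Among the three, compound 2 stands with the lowest number, and its gap to compound 3 lies beyond the usual scatter.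

The change from compound 3 to compound 1 is hydrogen in place of methyl on an oxygen on an aromatic ring, and it moves the number by an at least 1.0-fold higher number from compound 3 to compound 1 (0.03 log units; that floor lies within the scatter). Within the data shown here, because compound 1 sits at the limit of > 20000 nM in this assay, at which 1 of the 3 values shown sits, the true size of that step cannot be read from these data; only that the number did not fall is known.

Compound 4, `Cc1ccc(NC(=O)Nc2cc(C(F)(F)F)cc(C(F)(F)F)c2)cc1O`, is not yet measured. It arises from compound 2 by hydrogen in place of methyl on an oxygen on an aromatic ring, the same change that turned compound 3 into compound 1. The step from compound 2 to compound 4 is expected to be a 2.0-fold higher number from compound 2 to compound 4 (0.29 log units; within the scatter), resting on the weakening seen with compound 1, whose value > 20000 nM lies at the limit, set against the stronger starting point of compound 2 at 6600 nM. Compound 4 is therefore estimated at 13000 nM, with a range of 5000 nM to 40000 nM.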

Compound 4, half-maximal inhibitory concentration: 15700 nM
Compound 4: middle estimate off by 1.2-fold (0.08 log units), on the low side; the range from low to high includes it.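

In this assay, the change from methoxy to hydroxy on the core of compound 2 gives a 2.4-fold higher number from compound 2 to compound 4 (0.38 log units; beyond the scatter), a modest step. Set beside the same change on the core of compound 1, the number rises on one core and does not fall on the other, so the two results do not point in opposite directions: the same change on two cores in this assay, an at least 1.0-fold higher number (0.03 log units; that floor lies within the scatter) from compound 3 to compound 1 and a 2.4-fold higher number (0.38 log units; beyond the scatter) from compound 2 to compound 4; the limit leaves it open whether they differ. What this does not show is whether the change carries over with the same size, since compound 1 returns a limit and not a number: the limit of > 20000 nM in this assay, at which 1 of the 4 values shown sits.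

The compounds shown have only methoxy or hydroxy at this place, so they leave open how an ethoxy group, an amine or a carboxylic acid there would read in this assay. With just two cores behind the comparison, they also leave open whether the rise seen from methoxy to hydroxy would recur on any other core in this series.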